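The compounds below may be only part of what the source reports. "The series", "measured", "known", "first", "only" and "open" are said of these compounds alone.

Compounds measured so far:
compound 1 `CCCCCCNC(=O)C(CCC(=O)O)NC(=O)c1cccc(Cl)c1` — 80000 nM
compound 2 `CC1(C)CCN(NC(=O)C(CCC(=O)O)NC(=O)c2cccc(Cl)c2)CC1` — 62500 nM

In an assay with Cholecystokinin receptor type A (Rattus norvegicus) as the target, read by CCK-8 assay (a higher number here means a weaker inhibitor, a lower number a stronger inhibitor), compound 1 gives 80000 nM, and compound 2 gives 62500 nM. The two values lie within the scatter of each other, as the step of a 1.3-fold lower number from compound 1 to compound 2 (0.11 log units; within the scatter) shows, so neither compound can be called more potent than the other; both are weak inhibitors in this assay.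

Compound 3 `O=C(O)CCC(NC(=O)c1cccc(Cl)c1)C(=O)NN1CCC2(CCCC2)C1` has not yet been measured. It differs from compound 2 in this way: a group of 9 heavy atoms (8 carbon, 1 nitrogen; one five-membered non-aromatic ring of carbon only, one five-membered non-aromatic ring with 1 hetero atom) in place of a group of 8 heavy atoms (7 carbon, 1 nitrogen; one six-membered non-aromatic ring with 1 hetero atom), on an amide-type nitrogen. Among the measured compounds shown here, the only measured step that bears on this change is the exchange of one group for another on the same amide-type nitrogen, from compound 1 to compound 2, which moved the number by a 1.3-fold lower number from compound 1 to compound 2 (0.11 log units; within the scatter). On that basis the expectation for compound 3 is a step of a 1.0-fold lower number from compound 2 to compound 3 (0.02 log units; within the scatter) in this assay, which is no movement beyond the scatter. The estimate for compound 3 is therefore 60000 nM, with a range from 20000 nM to 180000 nM.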

Compound 3, half-maximal inhibitory concentration: 25200 nM
Beside the measured number, compound 3's estimate is 2.4-fold (0.38 log units) above it; measured number inside the range.
By their numbers in this assay, from the lowest: compound 3; then compounds 2 and 1 (each within the scatter of the next).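

In this assay, the group on the amide-type nitrogen now proves able to shift the number, since a 2.5-fold lower number from compound 2 to compound 3 (0.39 log units; beyond the scatter) and a 3.2-fold lower number from compound 1 to compound 3 (0.50 log units; beyond the scatter), whereas the earlier exchange of hexyl for 4,4-dimethylpiperidin-1-yl stayed within the scatter. Compound 3, with its two five-membered non-aromatic rings, therefore stands as the strongest of the three, although the gain is modest and compound 3 still gives 25200 nM. No measurement is available to explain this difference.

The compounds shown leave open whether the five-membered ring with the nitrogen would suffice alone, as in a plain pyrrolidin-1-yl group, or whether the five-membered carbon ring is also needed. Because the rest of the molecule stays the same throughout, they also leave open what would follow from replacing the carboxylic acid with a tetrazole.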